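The source may report more compounds than this note shows. Statements on the series, on what has been measured and on what is new or still open speak of the compounds shown alone.

The measured compounds:

Compound 1, `CC1(C)[C@@H]2CC[C@@]1(CS(=O)(=O)N1CCN(c3cc(C(F)(F)F)ccn3)CC1)C(=O)C2` — in a functional assay on CHO-K1 cells for antagonist activity at C-X-C chemokine receptor type 3 (Homo sapiens), read by FLIPR and calcium flux (a higher number here means a weaker inhibitor, a lower number a stronger inhibitor), compound 1 gives 25100 nM.
Compound 2, `Cc1ccc(N2CCN(S(=O)(=O)C[C@]34CC[C@H](CC3=O)C4(C)C)CC2)nc1` — in this assay compound 2 gives > 31600 nM, which is a limit of the assay.
Compound 3, `CC1(C)[C@@H]2CC[C@@]1(CS(=O)(=O)N1CCN(c3ccc(C#N)cn3)CC1)C(=O)C2` — in this assay compound 3 gives > 31600 nM, also a limit of the assay.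

Compound 3 therefore has no number of its own; it sits at the limit of > 31600 nM in this assay, at which 2 of the 3 values shown sit. The step of an at least 1.2-fold higher number from compound 1 to compound 3 (0.10 log units; that floor lies within the scatter) is known only as a floor, and the step of an at least 1.2-fold higher number from compound 1 to compound 2 (0.10 log units; that floor lies within the scatter) likewise. Between the two limits the step that the two limits leave unreadable from compound 2 to compound 3 cannot be read at all.

Compound 4, `CC(=O)c1ccc(N2CCN(S(=O)(=O)C[C@]34CC[C@H](CC3=O)C4(C)C)CC2)nc1`, differs from compound 3 by acetyl in place of cyano on an aromatic carbon. The measured steps that bear on this are the two aryl replacements from compound 1 and the cyano-for-methyl step, and none of them gives a readable size, since two of the three values are limits. The only firm fact is that changing the substituent on this pyridine has not yet lowered the number below that of compound 1.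

Compound 4 is expected to stay at or near the limit, giving an estimated 35000 nM in this assay, with a range from 12000 nM to 100000 nM. The expected step is a step that the limit leaves unreadable from compound 3 to compound 4, within the scatter.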

Compound 4, half-maximal inhibitory concentration: > 31600 nM
Compound 4 gave a limit, no number; the forecaster's own chance of this, stated with the estimate: 70%; the middle value is on the limit's open side.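

At this position on the pyridine, two atoms from the ring nitrogen and para to a large group, acetyl now joins methyl and cyano at the same limit in this assay, and this is a limit, not a number: the limit of > 31600 nM in this assay, at which 3 of the 4 values shown sit.

The steps between compound 2, compound 3 and compound 4 cannot be read, since each of these compounds has only a limit, so the three groups cannot be put in any order. Within the data shown here, the one step that can be read is an at least 1.2-fold higher number from compound 1 to compound 4 (0.10 log units; that floor lies within the scatter), which gives no firm separation between the 5-acetylpyridin-2-yl and 4-(trifluoromethyl)pyridin-2-yl groups.

From the compounds shown here alone, what remains open is whether any group at this position, such as an amine or a carboxylic acid, would give a number of its own in this assay rather than a limit. Also open, going by these compounds, is whether moving acetyl or cyano to the place that trifluoromethyl holds in compound 1 would do so.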